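From Compound 1 to Compound 3: A Nitrile Group Exchanged

The source may hold more compounds than are shown below. What is called first, only, known or untested is meant among the compounds shown, and "the series" means these compounds.

Compound 1 `N#CC12CC(CN([C@H](CCC(F)(F)F)C(N)=O)S(=O)(=O)c3ccc(Cl)cc3)(C1)C2` gives 30.2 10^-6 cm/s in an ADME assay on MDCKII-LE cells (Canis lupus familiaris) for permeability; on this read-out lower numbers stand for lower permeability and higher numbers for higher permeability. Among the measured compounds shown here, compound 2 `N#CCCCCN([C@H](CCC(F)(F)F)C(N)=O)S(=O)(=O)c1ccc(Cl)cc1` gives 24 10^-6 cm/s, so the two numbers available lie within the scatter of each other, and compound 1 stands level with its only measured neighbour. Compound 3 `N#C[C@@H]1C[C@H]1CN([C@H](CCC(F)(F)F)C(N)=O)S(=O)(=O)c1ccc(Cl)cc1` keeps the core of compound 1 and differs from it by a group of 5 heavy atoms (4 carbon, 1 nitrogen; one three-membered non-aromatic ring of carbon only) in place of a group of 7 heavy atoms (6 carbon, 1 nitrogen; 2 four-membered non-aromatic rings of carbon only), on a saturated chain carbon bound to a sulfonamide nitrogen. For the measured compounds named here, the incoming 2-cyanocyclopropyl carries 2 defined stereocentres, and the data hold no measured compound with this group. Going by the values given here, the one measured step that bears on the change exchanges the same position of compound 1 for a group without a ring: a 1.3-fold lower number from compound 1 to compound 2 (0.10 log units; within the scatter). On that single step, no change beyond the scatter is expected in this assay. The estimated step is a 1.2-fold lower number from compound 1 to compound 3 (0.08 log units; within the scatter). For compound 3 the expected value is 25 10^-6 cm/s, with an estimated range of 13 10^-6 cm/s to 42 10^-6 cm/s.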

Compound 3, apparent permeability: 9.94 10^-6 cm/s
Compound 3: middle estimate off by 2.5-fold (0.40 log units), on the high side; measured number below the stated range.
By their numbers in this assay, from the lowest: compound 3; then compounds 2 and 1 (each within the scatter of the next).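

In this assay, the position on a saturated chain carbon bound to a sulfonamide nitrogen proves sensitive to the group it carries, which the earlier pair could not show: that pair gave only a 1.3-fold lower number from compound 1 to compound 2 (0.10 log units; within the scatter). With 2-cyanocyclopropyl in place, the readings are a 3.0-fold lower number from compound 1 to compound 3 (0.48 log units; beyond the scatter) and a 2.4-fold lower number from compound 2 to compound 3 (0.38 log units; beyond the scatter), so keeping a nitrile in the group does not by itself hold the number, and the same counts of heavy atoms, hydrogen-bond donors and acceptors as 3-cyanopropyl do not either. Nothing measured here accounts for the lower number.

The compounds shown leave open whether the step goes with the three-membered ring, with its 2 defined stereocentres or with the nitrile on that ring. The other stereoisomers of 2-cyanocyclopropyl, and a plain cyclopropyl without the nitrile, would separate these.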